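Working notes: nitro in place of fluoro

The compounds below may be only part of what the source reports. "The series", "measured", "known", "first", "only" and "open" are said of these compounds alone.

The series is followed in a functional assay on NUGC-3 cells (Homo sapiens) for inhibition, read by sulforhodamine B assay (on this read-out higher numbers stand for weaker inhibition of growth and lower numbers for stronger inhibition of growth), and the numbers are thin. Compound 1 (`O=C(CCC1=CCCN(Cc2ccc(F)cc2)C1=O)NO`) has no usable entry there, its record reading "not determined" (no result reported), so it offers no number to start from. Going by the values given here, the only measured member is compound 2 (`O=C(CCC1=CCCN(CCCc2ccc(-c3ccccc3)cc2)C1=O)NO`), which stands at 3700 nM and carries a different side chain on the shared core.

The next member is compound 3 (`O=C(CCC1=CCCN(Cc2ccc([N+](=O)[O-])cc2)C1=O)NO`), which has nitro in place of fluoro on an aromatic carbon, para to a large group: nitro in place of fluoro on an aromatic carbon. Among the compounds with values here, no measured step bears on this exchange, and the missing result for compound 1 means that any step taken from it cannot be checked. Set against what compound 1 might have shown, the exchange is expected to produce no step beyond the scatter, in either direction.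

The estimate therefore rests loosely on compound 2 at 3700 nM, with weaker inhibition of growth expected and a wide margin kept. The estimated value for compound 3 is 12000 nM (expected range 3000 nM to 45000 nM).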

Compound 3, concentration for 50% growth inhibition: 1110 nM
Compound 3: middle estimate off by 11-fold (1.03 log units), on the high side; the measured number lies below the stated range.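

In this assay, going by these compounds alone, the entry for compound 1 is "not determined" (no result reported) and no step to compound 3 can be read from it. The compounds shown leave open how nitro in place of fluoro on the shared core changes inhibition of growth. Nothing at hand bears on the result for compound 3.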